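Swapping the aryl group on the shared core of compound 1

This account rests on a few compounds, and the source may have more. Where it says the series, first, only, none or still open, it means among the compounds named here.

Measured compounds:
- compound 1, `COc1ccc(C2=C(c3ccc(SC)cc3)CC3CCCN3C2=O)cc1C`: 100 nM
- compound 2, `COc1ccc(C2=C(c3ccc(SC)cc3)CC3CCCN3C2=O)cc1OC`: 2000 nM
- compound 3, `CSc1ccc(C2=C(c3ccc(O)cc3)C(=O)N3CCCC3C2)cc1`: limit, > 100000 nM

In a functional assay on NCI-H520 cells (Homo sapiens) for cytotoxicity (on this read-out higher numbers stand for weaker inhibition of growth and lower numbers for stronger inhibition of growth), compound 1 gives 100 nM, the lowest of the two plain numbers shown. Compound 2 sits well away from it, with a 20-fold higher number from compound 1 to compound 2 (1.30 log units; beyond the scatter). Compound 3 reaches only a limit of this assay, so no number is known for it; this is the limit of > 100000 nM in this assay, at which 1 of the 3 values shown sits.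

Compound 4, `CSc1ccc(C2=C(c3ccc(Br)cc3)C(=O)N3CCCC3C2)cc1`, has not been measured in this assay. Compared with compound 1 the change is 4-bromophenyl in place of 4-methoxy-3-methylphenyl on a double-bonded ring carbon.

Among the measured compounds shown here, two measured steps bear on this change, and both alter the same aryl group on the same double-bonded ring carbon. The first is a 20-fold higher number from compound 1 to compound 2 (1.30 log units; beyond the scatter), a small change to the group that nevertheless gave a large step. The second is an at least 1000-fold higher number from compound 1 to compound 3 (3.00 log units; beyond the scatter), where the whole group was replaced and the number moved past the limit. Both point the same way: changes at this position have raised the number strongly. For compound 4 the replacement is again of the whole group, so a large rise is expected, though it need not reach the limit.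

Compound 4 is therefore estimated at 5000 nM, with a likely range from 500 nM to 50000 nM, which corresponds to an expected 50-fold higher number from compound 1 to compound 4 (1.70 log units; beyond the scatter).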

Compound 4, concentration for 50% growth inhibition: 7000 nM
For compound 4 the middle estimate is 1.4-fold (0.15 log units) below the measured one; the measured number falls inside the stated range.
By their numbers in this assay, from the lowest: compound 1; then compound 2; then compound 4. At a limit, above all of these: compound 3.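

Compound 4 shows that replacing the whole 4-methoxy-3-methylphenyl group need not push the result to the limit: in this assay, 4-bromophenyl gives a 70-fold higher number from compound 1 to compound 4 (1.85 log units; beyond the scatter), a strong rise that still ends in a readable number. The group carried on the new aromatic ring also matters greatly, as bromo in place of hydroxy gives an at least 14-fold lower number from compound 3 to compound 4 (1.15 log units; beyond the scatter), so the outcome at this position does not depend on the presence of a phenyl ring alone. Compound 3 remains a limit of the assay and not a number: the limit of > 100000 nM in this assay, at which 1 of the 4 values shown sits.

The compounds shown leave open how an amine, a carboxylic acid or a longer chain such as ethoxy would behave in place of the bromo group, and whether any aryl group at this position can give a number lower than that of compound 1. They also leave open how a plain 4-methoxyphenyl group would compare, which would help separate what the methyl and the methoxy groups of compound 1 each contribute.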